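Swapping a Halogenated Benzyl Group on a Shared Core

The compounds below may be only part of what the source reports. "The series", "measured", "known", "first", "only" and "open" are said of these compounds alone.

Of the compounds shown here, two have been measured in an assay on isolated protein for inhibition of aldehyde dehydrogenase 1A1 (Homo sapiens), read by spectrophotometry, tested at 10 uM (on this read-out higher numbers stand for more inhibition at the one concentration tested (going by the name of the read-out) and lower numbers for less inhibition), so far. Compound 1, with the structure `O=C(C1CC1)N1CCN(Cc2nc3ccccc3n2Cc2ccccc2F)CC1`, gives 40.7%, the lower of the two numbers seen. Compound 2, with the structure `Cc1cccc(Cn2c(OC3CCN(C(=O)C4CC4)CC3)nc3ccccc32)c1`, gives 80.6% in this assay, a number well beyond the usual scatter above compound 1; the two differ in several places at once, so no single change can be read from that gap.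

Compound 3, with the structure `O=C(C1CC1)N1CCN(Cc2nc3ccccc3n2Cc2cccc(Cl)c2)CC1`, has not yet been tested. It keeps the core of compound 1 and differs in one place: 3-chlorophenyl in place of 2-fluorophenyl on a saturated chain carbon bound to an aromatic nitrogen. Both groups are six-membered aromatic rings of carbon only, each carrying one halogen, so the change is a small one at the edge of the molecule.

Going by the values given here, with no measured step of the same kind to lean on, the expected step is estimated as a number 9.3 percentage points higher from compound 1 to compound 3 (within the scatter), a modest rise in inhibition. Compound 3 is estimated to reach 50%, within a range from 25% to 75%.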

Compound 3, a percentage reported as inhibition, at one concentration (the size of the read-out at that concentration, not a potency): 71.6%
Compound 3: the middle estimate sits 21.6 percentage points below what was measured, and the stated range covers the measured number.
By their numbers in this assay, from the lowest: compound 1; then compounds 3 and 2 (each within the scatter of the next).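

Going by these compounds alone, this pair gives the first reading of a single change, since compound 1 and compound 3 differ in one place only. In this assay, 3-chlorophenyl in place of 2-fluorophenyl on a saturated chain carbon bound to an aromatic nitrogen gives a number 30.9 percentage points higher from compound 1 to compound 3 (beyond the scatter), so this position clearly matters for the read-out, even though both groups are six-membered aromatic rings of carbon only, each carrying one halogen. No measurement at hand explains why the number moves with this swap.

The swap changes the identity of the halogen and its place on the ring together, so these two compounds cannot show which of the two goes with the step. Also open, as far as these compounds go, is how the read-out would respond at this position to a plain phenyl ring without any halogen, to a bromine in place of the chlorine, or to a different kind of group altogether, such as a methoxy group or a carboxylic acid on the ring.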